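Boc-to-ethylpyrimidinyl swap on the spiro-piperidine series

The compounds below may be only part of what the source reports. "The series", "measured", "known", "first", "only" and "open" are said of these compounds alone.

Measured compounds, with solubility in a physicochemical assay for solubility, read by HPLC, in phosphate buffer, with a stated time of 24 h, at pH 6.8; a lower number here means a less soluble compound, a higher number a more soluble compound:
- compound 1 `CC(C)(C)OC(=O)N1CCC2(CC1)CC(CCCOc1ccc(S(C)(=O)=O)cc1)C2`: < 0.13 ug/mL, a limit of the assay, not a number
- compound 2 `CC1(OC(=O)N2CCC3(CC2)CC(CCCOc2ccc(S(C)(=O)=O)c(F)c2)C3)CC1`: < 0.15 ug/mL, again a limit
- compound 3 `CS(=O)(=O)c1ccc(OCCCC2CC3(CCN(C(=O)OC4CCCC4)CC3)C2)cc1F`: < 0.14 ug/mL, again a limit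

Compound 1 stands at the limit (the limit of < 0.13 ug/mL in this assay, at which 1 of the 3 values shown sits); compound 2 sits at the limit of < 0.15 ug/mL in this assay, at which 1 of the 3 values shown sits, and compound 3 at the limit of < 0.14 ug/mL in this assay, at which 1 of the 3 values shown sits, so none of the three gives a readable number. Going by the values given here, the one step in this assay between measured neighbours, a step that the two limits leave unreadable from compound 2 to compound 3, is therefore unreadable in size.

Compound 4 `CCc1cnc(N2CCC3(CC2)CC(CCCOc2ccc(S(C)(=O)=O)cc2)C3)nc1` differs from compound 1 by 5-ethylpyrimidin-2-yl in place of tert-butoxycarbonyl on an amine nitrogen in a ring. Among the compounds with values here, no measured step bears directly on this change, since the only measured step concerns the group on the oxygen of the carbamate, not its replacement by an aromatic ring on the ring nitrogen. For compound 4 the expected step of an at least 2.3-fold higher number from compound 1 to compound 4 (0.36 log units; beyond the scatter) is thus poorly grounded, and a value at or near the assay limit is expected for compound 4 as well, estimated at 0.3 ug/mL with a range from 0.05 ug/mL to 2 ug/mL.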

Compound 4, solubility: < 0.12 ug/mL
Compound 4 was reported as a limit (the forecaster's own chance of this, stated with the estimate: 55%); middle value at least 2.5-fold (0.39 log units) from the limit.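

In this assay compound 4 gives < 0.12 ug/mL, a limit and not a number. Compound 1 also stands at a limit, and the step between compound 1 and compound 4 cannot be read in size. The compounds shown leave open whether 5-ethylpyrimidin-2-yl in place of tert-butoxycarbonyl changes solubility at all.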